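The source may hold more compounds than are shown below. What is called first, only, known or untested is meant among the compounds shown, and "the series" means these compounds.

Compound 1 `CCN1CCN(C(=S)SCC(O)Cn2c([N+](=O)[O-])cnc2C)CC1` is the reference point of the series. In a toxicity assay on HeLa cells (Homo sapiens) for cytotoxicity, read by MTT assay, with a stated time of 24 h (a lower number here means a stronger inhibitor, a higher number a weaker inhibitor), compound 1 gives only a limit, > 5000000 nM. Compound 2 `COc1ccccc1N1CCN(C(=S)SCC(O)Cn2c([N+](=O)[O-])cnc2C)CC1` also gives only a limit in this assay, > 5000000 nM. The step that the two limits leave unreadable from compound 1 to compound 2 is therefore unreadable, since both values sit at the limit of > 5000000 nM in this assay, at which 2 of the 2 values shown sit. Compound 3 `Cc1ncc([N+](=O)[O-])n1CC(O)CSC(=S)N1CCCCC1` carries the change (piperidin-1-yl in place of 4-ethylpiperazin-1-yl on a thiocarbonyl carbon). Only the unreadable step bears on it, so no direction or size of step in this assay can be read from the measured pair. The expected step is a number no higher from compound 1 to compound 3 (the limit leaves the size open), most likely a limit again. Compound 3 is estimated at 5000000 nM, between 2000000 nM and 10000000 nM.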

Compound 3, half-maximal inhibitory concentration: 1400000 nM
The estimate for compound 3 lay 3.6-fold (0.55 log units) above the measured number, and the stated range ends above it.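

Setting piperidin-1-yl in place of 4-ethylpiperazin-1-yl on a thiocarbonyl carbon gives an at least 3.5-fold lower number from compound 1 to compound 3 (0.55 log units; beyond the scatter) in this assay. Going by these compounds alone, this is the first readable step and shows that the number responds to a change at this place, whereas the step between the two earlier compounds cannot be read. Compound 3 is the only compound shown that does not sit at the limit: the limit of > 5000000 nM in this assay, at which 2 of the 3 values shown sit.

The compounds shown leave open whether this step follows the loss of the ethyl group or of the second ring nitrogen. Also open, from the compounds shown here alone, is how an unsubstituted piperazin-1-yl or a morpholin-4-yl would read on the same carbon.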